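The compounds below may be only part of what the source reports. "The series", "measured", "known", "first", "only" and "open" are said of these compounds alone.

Compound 1 `Cc1nc(C)c([C@H](OC(C)(C)C)C(=O)O)c(N2CCC(C)(C)CC2)c1-c1ccc(-c2ccccc2)cc1` gives only a limit, not a number, in a toxicity assay on MT2 cells (Homo sapiens) for cytotoxicity, read by XTT assay, with a stated time of 4 days; a lower number here means that less compound is tolerated, a higher number that more compound is tolerated: >= 20000 nM.
Compound 2 `Cc1nc(C)c([C@H](OC(C)(C)C)C(=O)O)c(N2CCC(C)(C)CC2)c1-c1ccc(OCCc2cc(F)c(F)cc2F)cc1` likewise gives only a limit in this assay: >= 33500 nM.
Compound 3 `Cc1nc(C)c([C@H](OC(C)(C)C)C(=O)O)c(N2CCC(C)(C)CC2)c1-c1ccc(OC2CCCC2c2ccc(F)cc2)cc1` gives only limits in this assay: >= 32000 nM; >= 32000 nM (2 entries).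

Compound 2 therefore stands at a limit, and the two other values shown are limits as well, so no number places it among them. Among the measured compounds shown here, the one measured step touching it, a step that the two limits leave unreadable from compound 1 to compound 2, has two limits at its ends and its size cannot be read. The change to compound 4 `Cc1nc(C)c([C@H](OC(C)(C)C)C(=O)O)c(N2CCC(C)(C)CC2)c1-c1ccc(OCCc2ccncc2)cc1` is pyridin-4-yl in place of 2,4,5-trifluorophenyl on a saturated chain carbon, two bonds along the chain from an oxygen on an aromatic ring. For the measured compounds named here, no measured step covers this exchange, so no direction can be taken from the data. Since every value shown is a limit, compound 4 is expected to sit at a limit too, a step of roughly an at least 1.1-fold lower number from compound 2 to compound 4 (0.04 log units; that floor lies within the scatter). Compound 4 is estimated at 30000 nM, between 15000 nM and 60000 nM.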

Compound 4, half-maximal cytotoxic concentration: >= 25000 nM
Compound 4: a limit, no number; the forecaster's own chance of this, stated with the estimate: 80%; the middle value is on the limit's open side.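

Compound 4, like compound 1 and compound 2, gives only a limit, so no step among these three can be read. The compounds shown leave open what actual number any of them would reach in this assay.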